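Swapping tert-butyl for cyclopentyl in a glutamate receptor modulator

This account rests on a few compounds, and the source may have more. Where it says the series, first, only, none or still open, it means among the compounds named here.

Measured compounds:
- compound 1 `Cc1c(OCCCCOc2ccc(F)c(C(=O)O)c2)ccc(C(=O)CC(C)(C)C)c1O`: 94.6%
- compound 2 `Cc1c(OCCCCOc2ccc(C(=O)O)c(Cl)c2)ccc(C(=O)CC(C)C)c1C`: 33.1%
- compound 3 `Cc1c(OCCCCOc2ccc(C(=O)CC(C)(C)C)c(O)c2C)cccc1C(=O)O`: 95.8%

In an assay on HEK293 cells for positive allosteric modulation of metabotropic glutamate receptor 2 (Rattus norvegicus), read by thallium flux, with a stated time of 2.5 min (on this read-out lower numbers stand for smaller maximal responses and higher numbers for larger maximal responses), compound 1 gives 94.6%. Compound 3 lies within the scatter of it, as a number 1.2 percentage points higher from compound 1 to compound 3 (within the scatter) shows, while compound 2 gives 33.1% and stands far lower; compound 2 differs from compound 1 in more than one place, so its gap cannot be tied to a single change.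

Compound 4 `Cc1c(OCCCCOc2ccc(F)c(C(=O)O)c2)ccc(C(=O)CC2CCCC2)c1O` differs from compound 1 in one place: cyclopentyl in place of tert-butyl on a saturated chain carbon bound to a carbonyl carbon. For the measured compounds named here, no measured step touches this part of the shared core, so the only guide is the high response of compound 1 itself. Little movement beyond the scatter is expected, a number 6.6 percentage points lower from compound 1 to compound 4 (within the scatter). Compound 4 is therefore estimated at 88%, within 60% to 105%.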

Compound 4, largest response reached (reported as percent of maximum), in percent of the reference or control that the assay uses: 81%
Compound 4: middle estimate off by 7 percentage points, on the high side; measured number inside the range.
By their numbers in this assay, from the lowest: compound 2; then compound 4; then compounds 1 and 3 (each within the scatter of the next).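

For the compounds shown here, this is the first measured change at this spot, on a saturated chain carbon bound to a carbonyl carbon, and in this assay cyclopentyl in place of tert-butyl gives a number 13.6 percentage points lower from compound 1 to compound 4 (beyond the scatter) as a modest but real loss. The position therefore responds to the swap, yet compound 4 keeps a substantial maximal response. Nothing measured here explains the drop.

Going by these compounds, whether cyclopropyl or cyclohexyl at this place would stay closer to compound 1 remains open. So does the effect of an amine there.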